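The source may hold more compounds than are shown below. What is called first, only, known or untested is meant among the compounds shown, and "the series" means these compounds.

Working notes on the series. Among the compounds with values here, in a functional assay on L1210 cells (Mus musculus) for inhibition (a lower number here means a stronger inhibitor, a higher number a weaker inhibitor), compound 1 (`C#CCN(Cc1ccc2nc(C)nc(O)c2c1)c1ccc(C(=O)c2ccccc2)cc1`) gives 7700 nM as the only actual number so far. Compound 2 (`C#CCN(Cc1ccc2nc(C)nc(O)c2c1)c1ccc(C#N)c(C(F)(F)F)c1`) shows > 2800 nM as a limit and not a number. Compound 3 (`C#CCN(Cc1ccc2nc(C)nc(O)c2c1)c1ccc(S(=O)(=O)N2CCN(C)CC2)cc1`) shares the core of compound 1 and is still unmeasured. Its change is (4-methylpiperazin-1-yl)sulfonyl in place of benzoyl on an aromatic carbon, para to a large group ((4-methylpiperazin-1-yl)sulfonyl in place of benzoyl on an aromatic carbon). Within the data shown here, no measured step covers this kind of swap, so the expectation starts from compound 1 at 7700 nM and has nothing firmer behind it. In this assay the estimated step of a 1.4-fold higher number from compound 1 to compound 3 (0.15 log units; within the scatter) is expected to be small and perhaps within the scatter, with weaker inhibition the likelier direction. Compound 3 is estimated at 11000 nM with an expected range from 3500 nM to 35000 nM in this series.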

Compound 3, half-maximal inhibitory concentration: > 10000 nM
Compound 3: a limit, no number; the forecaster's own chance of this, stated with the estimate: 30%; the middle value does not contradict the limit.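

In this assay compound 3 reads > 10000 nM, which is a limit and not a number. For (4-methylpiperazin-1-yl)sulfonyl in place of benzoyl on this aromatic carbon, para to a large group, only a floor can be given, an at least 1.2-fold higher number from compound 1 to compound 3 (0.11 log units; that floor lies within the scatter), and that floor lies within the scatter, so the change cannot yet be called a real loss. It gives no sign of stronger inhibition at this position, and the size of any loss stays unread: the limit of > 10000 nM in this assay, at which 1 of the 3 values shown sits.

The compounds shown leave open how a carboxylic acid or a simple amine at this place would read. As far as these compounds go, it also remains open whether a dimethylamino group on the sulfonyl, in place of the piperazine ring, would give a number rather than a limit.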